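The source may hold more compounds than are shown below. What is called first, only, known or untested is meant among the compounds shown, and "the series" means these compounds.

Measured compounds:

compound 1 `O=S(=O)(NCCNCc1ccc(-c2ccccc2)cc1)c1cc(C(F)(F)F)cc(C(F)(F)F)c1`: 2700 nM
compound 2 `O=S(=O)(NCCCNCC1COc2ccccc2O1)c1cc(C(F)(F)F)cc(C(F)(F)F)c1`: 2800 nM
compound 3 `CC(C)(C)c1ccc(CNCCNS(=O)(=O)c2cc(C(F)(F)F)cc(C(F)(F)F)c2)cc1`: 14000 nM

In a functional assay on BE(2)-C cells (Homo sapiens) for inhibition, read by MTT assay, with a stated time of 72 h (a higher number here means a weaker inhibitor of growth, a lower number a stronger inhibitor of growth), compound 2 stands second highest of the three numbers. Its nearest neighbour is compound 1, which sits within the scatter of it; the furthest is compound 3, whose number lies beyond the scatter above both. Going by the values given here, the only one-place step measured here, a 5.2-fold higher number from compound 1 to compound 3 (0.71 log units; beyond the scatter), concerns a different change and does not touch the part of the molecule that changes between compound 2 and compound 4.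

Compound 4 `O=S(=O)(NCCCNCc1cccc(Cl)c1)c1cc(C(F)(F)F)cc(C(F)(F)F)c1` arises from compound 2 by 3-chlorophenyl in place of 2,3-dihydro-1,4-benzodioxin-2-yl on a saturated chain carbon bound to an amine nitrogen. Among the compounds with values here, no measured pair shows this kind of exchange, so the expectation rests on compound 2 alone, with compound 1 as a second point of the same order. The step of a 1.1-fold lower number from compound 2 to compound 4 (0.05 log units; within the scatter) is therefore expected to stay within the scatter, with no direction favoured. Compound 4 is estimated at 2500 nM, within a range of 900 nM to 7000 nM.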

Compound 4, concentration for 50% growth inhibition: 6900 nM
Compound 4: middle estimate off by 2.8-fold (0.44 log units), on the low side; the measured number falls inside the stated range.
By their numbers in this assay, from the lowest: compounds 1 and 2 (each within the scatter of the next); then compound 4; then compound 3.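

In this assay, the exchange at the saturated chain carbon bound to an amine nitrogen comes with a 2.5-fold higher number from compound 2 to compound 4 (0.39 log units; beyond the scatter), which shows that this place responds to the group it carries, though only modestly. The entering 3-chlorophenyl has fewer heavy atoms than the leaving 2,3-dihydro-1,4-benzodioxin-2-yl, lacks its non-aromatic ring and has no hydrogen-bond acceptors, yet this single exchange alters all of these at once and cannot assign the shift to any one of them. Nothing available gives a reason for the shift.

Going by these compounds, it remains open whether a 3-methoxyphenyl or a 3-fluorophenyl at this place would give a number closer to that of compound 2 or compound 4. Also open, on these data alone, is whether the chlorine contributes to the shift at all, a question that an unsubstituted phenyl at this place would address.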